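A Piperidine Tail Replaces the Methylpiperazine of Compound 3

The source may hold more compounds than are shown below. What is called first, only, known or untested is meant among the compounds shown, and "the series" means these compounds.

The account concerns three measured compounds sharing one core and one compound awaiting measurement. In a functional assay on SH-SY5Y cells (Homo sapiens) for cytotoxicity, read by MTT assay, with a stated time of 72 h (a higher number here means a weaker inhibitor, a lower number a stronger inhibitor), compound 3 `CN1CCN(CCCCn2c3c(c4ccccc42)C(=O)c2c[n+]([O-])c4ccccc4c2C3=O)CC1` gives 100 nM, the lowest of the two numbers recorded there. Compound 1 `CN(C)CCCCCn1c2c(c3ccccc31)C(=O)c1c[n+]([O-])c3ccccc3c1C2=O` gives 370 nM in this assay, and the difference is a 3.7-fold lower number from compound 1 to compound 3 (0.57 log units; beyond the scatter). Compound 2 `O=C1c2c[n+]([O-])c3ccccc3c2C(=O)c2c1c1ccccc1n2Cc1cn(C[C@H](O)CO)nn1` reaches only a limit of this assay, > 1000 nM. From that limit, an at least 10-fold lower number from compound 2 to compound 3 (1.00 log units; beyond the scatter), and an at least 2.7-fold higher number from compound 1 to compound 2 (0.43 log units; beyond the scatter).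

Compound 4 `O=C1c2c[n+]([O-])c3ccccc3c2C(=O)c2c1c1ccccc1n2CCCCN1CCCCC1` has not yet been measured in this assay. It differs from compound 3 in one place: piperidin-1-yl in place of 4-methylpiperazin-1-yl on a saturated chain carbon, four bonds along the chain from an aromatic nitrogen. Among the compounds with values here, the one measured step at this same place is a 3.7-fold lower number from compound 1 to compound 3 (0.57 log units; beyond the scatter), where one amine tail replaced another and the number fell modestly. Here again one amine ring replaces another, and each keeps a ring nitrogen bound to the chain; the writer therefore expects for compound 4 only a small shift, at most at the edge of the scatter, and an estimate of 180 nM with a range of 70 nM to 450 nM. The expected step is a 1.8-fold higher number from compound 3 to compound 4 (0.26 log units; within the scatter).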

Compound 4, half-maximal inhibitory concentration: 230 nM
For compound 4 the middle estimate is 1.3-fold (0.11 log units) below the measured one; the range from low to high includes it.
By their numbers in this assay, from the lowest: compound 3; then compounds 4 and 1 (each within the scatter of the next). At a limit, above all of these: compound 2.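

Compound 4 shows that the amine ring itself counts at this place, four bonds along the chain from an aromatic nitrogen: with a six-membered ring kept, a 2.3-fold higher number from compound 3 to compound 4 (0.36 log units; beyond the scatter) in this assay. The earlier step from compound 1 to compound 3 had exchanged an open dimethylamino end for a ring, whereas a 1.6-fold lower number from compound 1 to compound 4 (0.21 log units; within the scatter), so a ring alone does not separate a tail from that of compound 1. Compound 2 gives only a limit, so an at least 4.3-fold lower number from compound 2 to compound 4 (0.63 log units; beyond the scatter) is a bound and not a size: the limit of > 1000 nM in this assay, at which 1 of the 4 values shown sits.

Going by these compounds, what remains open is whether the methyl or the ring nitrogen bearing it accounts for the step from compound 3 to compound 4. An unsubstituted piperazin-1-yl or a morpholin-4-yl tail could separate the two, and a longer chain carrying piperidin-1-yl would test how far the result holds.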